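The compounds below may be only part of what the source reports. "The series", "measured", "known", "first", "only" and "open" are said of these compounds alone.

Measured in an ADME assay on the whole organism (strain Sprague-Dawley) for pharmacokinetics, with Rattus norvegicus as the target, at a dose of 5 mg/kg by the intravenous route; a lower number here means slower removal, a higher number faster removal of the compound:

- compound 1 `CC(C)c1ccc2c(Nc3cc(C(=O)N[C@@H](C)c4ccccc4)ccc3Sc3ccc(N)cc3)ncnc2n1`: 5.5 mL/min/kg
- compound 2 `CC(C)c1ccc2c(Nc3cc(C(=O)N[C@@](C)(CO)c4ccccc4)ccc3Sc3ccc(N)cc3)ncnc2n1`: 12.5 mL/min/kg
- compound 3 `CC(C)c1ccc2c(Nc3cc(C(=O)N[C@@H](C)c4ccc(Br)cc4)ccc3Sc3ccc(N)cc3)ncnc2n1`: 5.67 mL/min/kg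

Compound 2 has the highest number of the three. Compound 4 `CC(C)c1ccc2c(Nc3cc(C(=O)N[C@@H](C)C4CCCCC4)ccc3Sc3ccc(N)cc3)ncnc2n1` departs from it by 1-cyclohexylethyl in place of 1-(hydroxymethyl)-1-phenylethyl on an amide-type nitrogen. Among the compounds with values here, two measured steps bear on this, both modest. Adding the hydroxymethyl gave a 2.3-fold higher number from compound 1 to compound 2 (0.36 log units; beyond the scatter), and the swap to 1-(4-bromophenyl)ethyl gave a 2.2-fold lower number from compound 2 to compound 3 (0.34 log units; beyond the scatter). The bromo change, a 1.0-fold higher number from compound 1 to compound 3 (0.01 log units; within the scatter), stayed within the scatter. Like compound 1 and compound 3, compound 4 carries no hydroxymethyl. A modest fall is therefore expected, a 1.8-fold lower number from compound 2 to compound 4 (0.25 log units; within the scatter). Within the data shown here, no measured step tests a cyclohexyl ring in place of a phenyl ring, so the range stays wide. For compound 4 the estimate is 7 mL/min/kg, with an expected range from 3.5 mL/min/kg to 14 mL/min/kg.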

Compound 4, clearance: 21.5 mL/min/kg
Compound 4: the middle estimate sits 3.1-fold (0.49 log units) below what was measured, outside the stated range (above it).
By their numbers in this assay, from the lowest: compounds 1 and 3 (each within the scatter of the next); then compounds 2 and 4 (each within the scatter of the next).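

In this assay, cyclohexyl in place of phenyl on the saturated chain carbon gives a 3.9-fold higher number from compound 1 to compound 4 (0.59 log units; beyond the scatter), and cyclohexyl in place of 4-bromophenyl gives a 3.8-fold higher number from compound 3 to compound 4 (0.58 log units; beyond the scatter), so this ring change moves the number where the bromo change did not. The step of a 1.7-fold higher number from compound 2 to compound 4 (0.24 log units; within the scatter) shows that a group without hydroxymethyl can reach the level of compound 2 on this amide-type nitrogen. Nothing given here accounts for these shifts in clearance.

Open, on these data alone, is how a cyclopentyl or piperidinyl ring would fare here. Also open, as far as these compounds go, is what hydroxymethyl would do on the 1-cyclohexylethyl group.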